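Ring-nitrogen substituent change in a pyrazolyl urea series

The source may report more compounds than this note shows. Statements on the series, on what has been measured and on what is new or still open speak of the compounds shown alone.

Measured so far in an assay on isolated protein for inhibition of serine/threonine-protein kinase 10 (Homo sapiens), read by thermal shift assay, tested at 10 uM; on this read-out higher numbers stand for stronger stabilisation of the target against heat and lower numbers for weaker stabilisation of the target:
compound 1, `CC(C)(C)c1cc(NC(=O)Nc2ccccc2)n(-c2ccccc2)n1`, 7.2 degrees C
compound 2, `COc1cccc(NC(=O)Nc2cc(C(C)(C)C)nn2-c2ccccc2)c1`, 3.7 degrees C
compound 3, `CC(C)(C)c1cc(NC(=O)Nc2cc(F)cc(F)c2)n(-c2ccccc2)n1`, 2.5 degrees C

Compound 3 stands lowest of the three numbers in this assay: compound 2 lies nearest, a number 1.2 degrees C lower from compound 2 to compound 3 (beyond the scatter), and compound 1 furthest, a number 4.7 degrees C lower from compound 1 to compound 3 (beyond the scatter). The remaining measured step, a number 3.5 degrees C lower from compound 1 to compound 2 (beyond the scatter), concerns the same aryl on the amide-type nitrogen.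

Compound 4, `Cn1nc(C(C)(C)C)cc1NC(=O)Nc1cc(F)cc(F)c1`, differs from compound 3 in one place: methyl in place of phenyl on an aromatic nitrogen. None of the three measured steps touches the aromatic nitrogen of the five-membered ring; all three vary the group on the amide-type nitrogen while the phenyl on the ring nitrogen is kept. The data therefore give no direct guide for the direction or size of this step, and the estimate for compound 4 is anchored on compound 3 with a wide range.

Compound 4 is expected to give about 1.5 degrees C in this assay, within -1 degrees C to 4 degrees C. This corresponds to an expected step of a number 1.0 degrees C lower from compound 3 to compound 4 (within the scatter), with the direction uncertain.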

Compound 4, shift of the target's melting temperature: 1.1 degrees C
Compound 4: the middle estimate sits 0.40 degrees C above what was measured, and the stated range covers the measured number.
By their numbers in this assay, from the lowest: compound 4; then compound 3; then compound 2; then compound 1.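

The aromatic nitrogen of the five-membered ring now has a read-out of its own: in this assay, methyl in place of phenyl gives a number 1.4 degrees C lower from compound 3 to compound 4 (beyond the scatter). For the compounds shown here, the phenyl at this position therefore counts towards the number, and the earlier compounds, which varied only the group on the amide-type nitrogen, could not show this. Nothing available explains this step.

From the compounds shown here alone, this step has been read only with 3,5-difluorophenyl on the amide-type nitrogen, so it remains open whether methyl in place of phenyl would move the number in the same direction and by a similar amount with the unsubstituted phenyl of compound 1 there. Also open, going by these compounds, is how the aromatic nitrogen would respond to an ethyl, a benzyl or a pyridyl group.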